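The source may report more compounds than this note shows. Statements on the series, on what has been measured and on what is new or still open speak of the compounds shown alone.

In a functional assay on HOS-TE85 cells (Homo sapiens) for inhibition, read by CCK-8 assay, with a stated time of 72 h (a lower number here means a stronger inhibitor, a higher number a weaker inhibitor), three compounds sharing one core have been measured. Compound 1 `O=C(NCCCCc1ccccc1)c1cccc(C2SCC(=O)N2c2cnccn2)c1` gives > 1000 nM, and this is a limit of the assay, not a number. Compound 2 `COc1ccc(F)cc1N1C(=O)CSC1c1cccc(C(=O)NCCCCc2ccccc2)c1` gives 8.8 nM. Compound 3 `COc1cc(F)ccc1N1C(=O)CSC1c1cccc(C(=O)NCCCCc2ccccc2)c1` gives 71.1 nM, the higher of the two actual numbers. Compound 4 `C#Cc1cccc(N2C(=O)CSC2c2cccc(C(=O)NCCCCc3ccccc3)c2)c1` differs from compound 3 at one place: 3-ethynylphenyl in place of 4-fluoro-2-methoxyphenyl on an amide-type nitrogen in a ring. Among the compounds with values here, all the measured steps fall at this same place on the core, and none involves 3-ethynylphenyl. Replacing pyrazin-2-yl gave large steps, an at least 110-fold lower number from compound 1 to compound 2 (2.05 log units; beyond the scatter) and an at least 14-fold lower number from compound 1 to compound 3 (1.14 log units; beyond the scatter). Exchanging one fluoro-methoxyphenyl group for the other gave a modest one, an 8.1-fold higher number from compound 2 to compound 3 (0.91 log units; beyond the scatter). The entering group keeps the carbon-only aromatic ring of compound 3, so the modest step, rather than the large ones, is taken as the guide to the likely size of change. No direction is firmly indicated, and only a slight rise is expected, which is estimated as a 1.1-fold higher number from compound 3 to compound 4 (0.05 log units; within the scatter). For compound 4, the estimated value is 80 nM, with an expected range from 10 nM to 640 nM.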

Compound 4, half-maximal inhibitory concentration: 149 nM
For compound 4 the middle estimate is 1.9-fold (0.27 log units) below the measured one, within the range that was stated.
By their numbers in this assay, from the lowest: compound 2; then compound 3; then compound 4. At a limit, above all of these: compound 1.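

In this assay, a methoxy group and a fluorine are not required on the amide-type nitrogen for a measurable number: 3-ethynylphenyl carries neither, yet gives an at least 6.7-fold lower number from compound 1 to compound 4 (0.82 log units; beyond the scatter). That step starts from a limit, not a number: the limit of > 1000 nM in this assay, at which 1 of the 4 values shown sits. Even so, 3-ethynylphenyl does not match either fluoro-methoxyphenyl group, with a 2.1-fold higher number from compound 3 to compound 4 (0.32 log units; beyond the scatter) and a 17-fold higher number from compound 2 to compound 4 (1.23 log units; beyond the scatter), so the larger loss is measured against the 5-fluoro-2-methoxyphenyl group and the smaller against the 4-fluoro-2-methoxyphenyl group.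

As far as these compounds go, how much of the number for compound 4 belongs to the ethynyl group itself, and how much to the carbon-only aromatic ring, stays open. A plain phenyl on this nitrogen, or a nitrile or an ethyl in place of the ethynyl group, could separate the two.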